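Sulfanyl acid replacing the saturated ethyl ester chain

The compounds below may be only part of what the source reports. "The series", "measured", "known", "first", "only" and "open" are said of these compounds alone.

Measured compounds:
compound 1 `CCCCC1([C@H](O)/C=C/C2CCC(=O)[C@@H]2C/C=C\CCCC(=O)O)CCC1` – 0.00767 mg/kg
compound 2 `CCCCC1([C@H](O)/C=C/C2CCC(=O)[C@@H]2CCCCCCC(=O)OCC)CCC1` – 0.409 mg/kg
compound 3 `CCCCC1([C@H](O)/C=C/C2CCC(=O)[C@@H]2C/C=C\CCCC(=O)OCC)CCC1` – 0.135 mg/kg

In a functional assay on the whole organism (strain Hartley) for inhibition, with Cavia porcellus as the target, with stated times of 15 min and 2 min (a higher number here means that more compound is needed for the effect, a lower number that less compound is needed), compound 2 gives the highest number of the three; compound 3 stands nearest to it and compound 1 furthest, both steps beyond the scatter. The unmeasured compound 4 `CCCCC1([C@H](O)/C=C/C2CCC(=O)[C@@H]2CCCCSCC(=O)O)CCC1` differs from compound 2 in one place: (carboxymethyl)sulfanyl in place of 2-(ethoxycarbonyl)ethyl on a saturated chain carbon, four bonds along the chain from a saturated ring carbon.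

Within the data shown here, the one measured step that bears on this change is the conversion of the free acid into the ethyl ester, an 18-fold higher number from compound 1 to compound 3 (1.25 log units; beyond the scatter), a large rise in this assay. Compound 4 runs the other way, from ester back to free acid, while also exchanging a chain carbon for sulfur. Among the measured compounds shown here, no measured pair speaks to the sulfur exchange, so the acid step is the only guide, and its size is taken with some caution.

Compound 4 is therefore expected to need less compound than compound 2, with an expected step of a 9.1-fold lower number from compound 2 to compound 4 (0.96 log units; beyond the scatter). The estimate for compound 4 in this assay is 0.045 mg/kg, with a range of 0.01 mg/kg to 0.18 mg/kg.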

Compound 4, dose for half-maximal effect: 0.171 mg/kg
Beside the measured number, compound 4's estimate is 3.8-fold (0.58 log units) below it; low and high end bracket the measured number.
By their numbers in this assay, from the lowest: compound 1; then compounds 3 and 4 (each within the scatter of the next); then compound 2.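

In this assay, (carboxymethyl)sulfanyl in place of 2-(ethoxycarbonyl)ethyl gives only a 2.4-fold lower number from compound 2 to compound 4 (0.38 log units; beyond the scatter), a modest change at this position of the saturated chain. Against the unsaturated acid, 3-((carboxymethyl)sulfanyl)propyl in place of 5-carboxypent-1-en-1-yl gives a 22-fold higher number from compound 1 to compound 4 (1.35 log units; beyond the scatter), so among these compounds a free acid alone does not bring the number down to that of compound 1. Nothing at hand accounts for this difference between the two acid chains.

Compound 4 changes the sulfur and the free acid together, so the ethyl ester of compound 4 and the saturated all-carbon chain ending in a carboxylic acid would be needed to separate their shares of the step. Going by these compounds, how an ether oxygen in place of the sulfur, or a longer chain, would read in this assay also stays open.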